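The source may report more compounds than this note shows. Statements on the series, on what has been measured and on what is new or still open speak of the compounds shown alone.

In a toxicity assay on NIH3T3 cells (Mus musculus) for cytotoxicity, read by resazurin assay (a higher number here means that more compound is needed for the effect, a lower number that less compound is needed), compound 1 (`CC(=O)c1ccc(NCc2cncn2Cc2ccc(-c3ccccc3)cc2)cc1-c1ccccc1`) gives > 10000 nM, which is a limit and not a number. Compound 2 (`CNC(=O)c1ccc(NCc2cncn2Cc2ccc(-c3ccccc3)cc2N)cc1-c1ccccc1`) gives > 1000 nM, which is also a limit. Compound 3 (`COC(=O)c1ccc(NCc2cncn2Cc2ccccc2)cc1-c1ccccc1`) gives > 1000 nM, again a limit. Compound 1 therefore stands at a limit, and none of the three compounds has a numerical value. Compound 4 (`N#Cc1ccc(NCc2cncn2Cc2ccc(-c3ccccc3)cc2)cc1-c1ccccc1`) has cyano in place of acetyl on an aromatic carbon, ortho to a phenyl group and para to a large group: cyano in place of acetyl on an aromatic carbon. No measured step sizes this change, so no shift beyond the scatter is expected in this assay, and the expected step is a number no higher from compound 1 to compound 4 (the limit leaves the size open). For compound 4 the estimated value is 10000 nM, with an expected range from 3000 nM to 30000 nM.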

Compound 4, half-maximal effective concentration: > 1000 nM
Compound 4 ended at the assay's limit (the forecaster's own chance of this, stated with the estimate: 70%); the middle value is on the limit's open side.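

Among the compounds shown here, compound 1 and compound 4 both stand at limits and not numbers in this assay, and no step between them can be read. The compounds shown leave open whether cyano in place of acetyl changes this read-out at all.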